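Chloro to fluoro on compound 2

The compounds below may be only part of what the source reports. "The series", "measured", "known", "first", "only" and "open" are said of these compounds alone.

Measured compounds, with values in an ADME assay on GES1 cells (Homo sapiens) for inhibition, read by MTT assay, with a stated time of 72 h; a lower number here means a stronger inhibitor, a higher number a weaker inhibitor:
Compound 1 `Cc1cc(Nc2cc(C(C)(C)C)[nH]n2)n2nc(SCc3ccc(Br)cc3)nc2n1` gives > 50000 nM (a limit of the assay)
Compound 2 `Cc1cc(Nc2cc(-c3ccc(Cl)cc3)[nH]n2)n2nc(SCc3ccc(Br)cc3)nc2n1` gives 28200 nM

Within the data shown here, compound 2 carries the only actual number so far, since compound 1 reports only a limit of the assay. In this assay compound 2 gives 28200 nM as its reading, and a higher number means a weaker inhibitor.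

Compound 3 `Cc1cc(Nc2cc(-c3ccc(F)cc3)[nH]n2)n2nc(SCc3ccc(Br)cc3)nc2n1` differs from compound 2 in a single swap: fluoro in place of chloro on an aromatic carbon (fluoro in place of chloro on an aromatic carbon, para to a large group).

Among the measured compounds shown here, the one measured step is an at least 1.7-fold lower number from compound 1 to compound 2 (0.24 log units; that floor lies within the scatter) and it bears on this swap only loosely. That step exchanged tert-butyl for a whole 4-chlorophenyl, a far larger change than one halogen for another, and its floor lies within the scatter. With compound 2 at 28200 nM and no measurement of this swap itself, no shift beyond the scatter is expected. The estimated step is a 1.1-fold higher number from compound 2 to compound 3 (0.05 log units; within the scatter) and it is expected to stay within the scatter. Compound 3 is estimated at 32000 nM in this assay, with an expected range from 16000 nM to 50000 nM for its reading.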

Compound 3, half-maximal inhibitory concentration: 34200 nM
Compound 3: the middle estimate sits 1.1-fold (0.03 log units) below what was measured; the range from low to high includes it.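

In this assay, the change from 4-chlorophenyl to 4-fluorophenyl gives a 1.2-fold higher number from compound 2 to compound 3 (0.08 log units; within the scatter), so at this aromatic carbon, para to a large group, the two halogens cannot be told apart in this assay. Among these compounds, this is the first direct reading of a change at this position, and it shows that replacing chloro with fluoro, one halogen atom for another, leaves the reading within the usual scatter. The exchange of the tert-butyl group for 4-fluorophenyl gives an at least 1.4-fold lower number from compound 1 to compound 3 (0.16 log units; that floor lies within the scatter), and like the earlier step to the 4-chlorophenyl compound it fixes only a floor, so compound 1 cannot be ranked against either aryl compound: the limit of > 50000 nM in this assay, at which 1 of the 3 values shown sits.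

On these data alone, two halogens say little about the position as a whole, so it remains open whether an amine, a carboxylic acid or a longer chain on this same carbon would move the reading beyond the scatter, and what plain hydrogen there would give. As far as these compounds go, the rest of the structure is the same in all three compounds, so the effect of changes elsewhere on the shared core also stays open.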